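The compounds below may be only part of what the source reports. "The series", "measured", "known", "first", "only" and "open" are said of these compounds alone.

Measured compounds and their values in a functional assay on HL-60 cells (Homo sapiens) for antiproliferative activity, with a stated time of 72 h; a lower number here means a stronger inhibitor, a higher number a weaker inhibitor:

Compound 1 `OC[C@H]1O[C@@H](n2cnc3c(NCc4cccc(F)c4)ncnc32)[C@H](O)[C@@H]1O` gives 920 nM in this assay.
Compound 2 `OC[C@H]1O[C@@H](n2cnc3c(NCc4ccccc4Cl)ncnc32)[C@H](O)[C@@H]1O` gives 1600 nM in this assay.

Going by the values given here, compound 2 stands at the highest of the two numbers so far, but its only neighbour is compound 1, and the step of a 1.7-fold higher number from compound 1 to compound 2 (0.24 log units; within the scatter) lies within the scatter, so the two cannot be ordered with confidence. Compound 3 `COc1cccc(CNc2ncnc3c2ncn3[C@@H]2O[C@H](CO)[C@@H](O)[C@H]2O)c1OC` differs from compound 2 by 2,3-dimethoxyphenyl in place of 2-chlorophenyl on a saturated chain carbon bound to a nitrogen on an aromatic ring.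

Among the compounds with values here, one measured step bears on this change: a 1.7-fold higher number from compound 1 to compound 2 (0.24 log units; within the scatter) exchanged one substituted phenyl group for another on the same saturated chain carbon bound to a nitrogen on an aromatic ring, the same place that changes from compound 2 to compound 3, and it did not move the number beyond the scatter. On that basis the exchange of the 2-chlorophenyl for the 2,3-dimethoxyphenyl is expected to give at most a small step, a 1.1-fold lower number from compound 2 to compound 3 (0.06 log units; within the scatter), in no particular direction. Compound 3 is therefore estimated at 1400 nM, with a range from 500 nM to 4000 nM.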

Compound 3, half-maximal inhibitory concentration: > 166000 nM
Compound 3: no number, only a limit; the forecaster's own chance of this, stated with the estimate: 5%; at least 110-fold (2.07 log units) between middle value and limit.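

In this assay, the group on the saturated chain carbon bound to a nitrogen on an aromatic ring turns out to matter a great deal: 2,3-dimethoxyphenyl in place of 2-chlorophenyl gives an at least 100-fold higher number from compound 2 to compound 3 (2.01 log units; beyond the scatter), and in place of 3-fluorophenyl it gives an at least 180-fold higher number from compound 1 to compound 3 (2.25 log units; beyond the scatter). The earlier exchange of one substituted phenyl for another, a 1.7-fold higher number from compound 1 to compound 2 (0.24 log units; within the scatter), gave no sign of this, so the position tolerates some substituted phenyl groups but not every one. The value of compound 3 is a limit and not a number, so these steps give only a lower bound on the change: the limit of > 166000 nM in this assay, at which 1 of the 3 values shown sits.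

The entering group differs from the two it replaces both in its heavy atoms and in bringing hydrogen-bond acceptors, and the compounds shown do not separate these differences or tell whether one methoxy group alone would have the same effect. Going by these compounds, a phenyl carrying a single methoxy or a hydroxyl group at this place would bear on that question, and how far below the limit of compound 3 any such compound falls remains open.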